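Fluoro for trifluoromethyl on the sulfonyl aryl ring

The compounds below may be only part of what the source reports. "The series", "measured", "known", "first", "only" and "open" are said of these compounds alone.

Among the measured compounds shown here, the series shares one core, an amide-linked benzylic sulfone; the three members measured so far are compound 1 `Cc1cccc(S(=O)(=O)c2ccc(CNC(=O)c3cc4cnccc4[nH]3)cc2)c1`, compound 2 `O=C(NCc1ccc(S(=O)(=O)c2ccc(F)c(F)c2)cc1)c1cc2cnccc2[nH]1` and compound 3 `O=C(NCc1ccc(S(=O)(=O)c2cccc(C(F)(F)F)c2)cc1)c1cc2cnccc2[nH]1`. In an ADME assay on microsomes from liver (Mus musculus) for metabolic stability, read by LC-MS, with a stated time of 30 min, tested at 1 uM (on this read-out lower numbers stand for a less stable compound and higher numbers for a more stable compound), compound 1 gives 32%, compound 2 gives 58% and compound 3 gives 49%. Compound 3 stands second highest of the three numbers: its gap to compound 2 is within the scatter, as shown by a number 9 percentage points lower from compound 2 to compound 3 (within the scatter), while its gap to compound 1 is beyond it, shown by a number 17 percentage points higher from compound 1 to compound 3 (beyond the scatter). The further step a number 26 percentage points higher from compound 1 to compound 2 (beyond the scatter) also lies beyond the scatter.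

The next member is compound 4 `O=C(NCc1ccc(S(=O)(=O)c2cccc(F)c2)cc1)c1cc2cnccc2[nH]1`. Its difference from compound 3 is fluoro in place of trifluoromethyl on an aromatic carbon. For the measured compounds named here, two measured steps bear on this: the exchange of methyl for trifluoromethyl, a number 17 percentage points higher from compound 1 to compound 3 (beyond the scatter), and the exchange of the difluorinated ring for the trifluoromethyl-bearing one, a number 9 percentage points lower from compound 2 to compound 3 (within the scatter). Neither reproduces a single fluorine in this position, so the bearing is indirect; the three numbers cluster in a narrow band, and a step beyond the scatter in either direction is not expected. For compound 4 the expected step in this assay is a number 1 percentage points higher from compound 3 to compound 4 (within the scatter). Compound 4 is therefore estimated at 50%, with a range from 35% to 65%.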

Compound 4, percent of the compound remaining: 44%
Compound 4: the middle estimate sits 6 percentage points above what was measured; measured number inside the range.
By their numbers in this assay, from the lowest: compound 1; then compounds 4, 3 and 2 (each within the scatter of the next, the first and the last beyond it).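

In this assay this aromatic carbon, meta to a large group, tolerates a change from trifluoromethyl to fluoro, a loss of 4 heavy atoms for 1, with a number 5 percentage points lower from compound 3 to compound 4 (within the scatter); the size of the group therefore cannot be separated from the scatter at this place. The 3-fluorophenyl ring of compound 4 still reads apart from both other neighbours, with a number 12 percentage points higher from compound 1 to compound 4 (beyond the scatter) on fluoro in place of methyl and a number 14 percentage points lower from compound 2 to compound 4 (beyond the scatter) on hydrogen in place of fluoro, so both changes are visible here, although compound 3 stays within the scatter of compound 2 and of compound 4. No measurement at hand explains any of these steps.

Open, from the compounds shown here alone, is how a nitrile, a methoxy group or an amine on this same aromatic carbon would read in this assay, and whether an unsubstituted phenyl ring would fall with compound 1 or with compound 4. Also open, going by these compounds, is whether these steps on the sulfonyl aryl ring hold when the rest of the shared core is changed, for example with a longer chain in place of the benzylic linker.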